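The source may hold more compounds than are shown below. What is called first, only, known or untested is meant among the compounds shown, and "the series" means these compounds.

Compound 2 `COc1ccc(-c2c(C(=O)c3cc(OC)c(OC)c(OC)c3)sc3ccccc23)cc1` gives 1600 nM in a functional assay on Jurkat cells (Homo sapiens) for antiproliferative activity, read by MTT assay, with a stated time of 72 h; a higher number here means a weaker inhibitor, a lower number a stronger inhibitor. Among the three measured compounds it holds the lowest number: compound 3 `COc1cc(C(=O)c2sc3ccccc3c2-c2ccc(SC)cc2)cc(OC)c1OC` gives 1900 nM, and the difference a 1.2-fold higher number from compound 2 to compound 3 (0.07 log units; within the scatter) is within the scatter; compound 1 `COc1cc(C(=O)c2sc3ccccc3c2-c2ccc(C)cc2)cc(OC)c1OC` gives 3300 nM, and the step of a 2.1-fold lower number from compound 1 to compound 2 (0.31 log units; beyond the scatter) is beyond the scatter.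

Compound 4 `CCOc1ccc(-c2c(C(=O)c3cc(OC)c(OC)c(OC)c3)sc3ccccc23)cc1` differs from compound 2 by methyl in place of hydrogen on a saturated chain carbon bound to an oxygen on an aromatic ring.

The measured steps all vary the group on the same aromatic carbon of the pendant ring: a 2.1-fold lower number from compound 1 to compound 2 (0.31 log units; beyond the scatter), a 1.7-fold lower number from compound 1 to compound 3 (0.24 log units; within the scatter) and a 1.2-fold higher number from compound 2 to compound 3 (0.07 log units; within the scatter). Going by the values given here, none lengthens a chain on an oxygen already present, so the step from compound 2 to compound 4 has no direct precedent. Among the compounds with values here, the three measured groups at that site span a narrow range, with only one step beyond the scatter, so the expectation is a step from compound 2 to compound 4 of a 1.3-fold higher number from compound 2 to compound 4 (0.10 log units; within the scatter), in effect none beyond the scatter. For compound 4 the estimated value in this assay is 2000 nM, with a range from 800 nM to 5000 nM.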

Compound 4, half-maximal inhibitory concentration: 4100 nM
Compound 4: middle estimate off by 2.1-fold (0.31 log units), on the low side; low and high end bracket the measured number.
By their numbers in this assay, from the lowest: compounds 2, 3, 1 and 4 (each within the scatter of the next, the first and the last beyond it).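

Adding one methyl to the saturated chain carbon bound to the oxygen on the aromatic ring, turning methoxy into ethoxy, moves the number in this assay beyond the scatter (a 2.6-fold higher number from compound 2 to compound 4 (0.41 log units; beyond the scatter)), so this site responds to the length of the chain on the oxygen and not only to the group attached directly to the aromatic carbon. Ethoxy also separates from methylsulfanyl (a 2.2-fold higher number from compound 3 to compound 4 (0.33 log units; beyond the scatter)) but not from methyl (a 1.2-fold higher number from compound 1 to compound 4 (0.09 log units; within the scatter)), which leaves compound 4 and compound 1 indistinguishable in this assay. No measured evidence bears on the reason for these steps.

Going by these compounds, whether a longer chain such as propoxy would move the number further remains open. So does the outcome of a free hydroxy group or an amine on the same aromatic carbon.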